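This account rests on a few compounds, and the source may have more. Where it says the series, first, only, none or still open, it means among the compounds named here.

Antiproliferative readings so far in a functional assay on PC-3 cells (Homo sapiens) for antiproliferative activity, read by MTT assay, with a stated time of 48 h; a higher number here means a weaker inhibitor, a lower number a stronger inhibitor:

compound 1 `COc1ccc(CN(C(=O)Cn2cc(COc3ccccc3)nn2)c2cc(OC)c(OC)c(OC)c2)cc1`: 45300 nM
compound 2 `COc1ccc(CN(C(=O)Cn2cc(CSc3nc4ccccc4o3)nn2)c2cc(OC)c(OC)c(OC)c2)cc1`: 5050 nM
compound 3 `COc1ccc(CN(C(=O)Cn2cc(CNS(=O)(=O)c3ccc(C)cc3)nn2)c2cc(OC)c(OC)c(OC)c2)cc1`: 12400 nM

Compound 1 stands highest of the three numbers. The two measured steps leading away from it are a 3.7-fold lower number from compound 1 to compound 3 (0.56 log units; beyond the scatter) and a 9.0-fold lower number from compound 1 to compound 2 (0.95 log units; beyond the scatter), both beyond the scatter, the second the larger. Between the two lower compounds the step is a 2.5-fold higher number from compound 2 to compound 3 (0.39 log units; beyond the scatter).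

The next compound, compound 4 `COc1ccc(CN(C(=O)Cn2cc(CNS(=O)(=O)c3ccc(Br)cc3)nn2)c2cc(OC)c(OC)c(OC)c2)cc1`, has not yet been measured. Its change from compound 1 is ((4-bromophenyl)sulfonyl)amino in place of phenoxy on a saturated chain carbon bound to an aromatic carbon. Going by the values given here, the step that bears most directly on it is the one to compound 3, where ((4-methylphenyl)sulfonyl)amino replaced phenoxy at the same place; compound 3 and compound 4 differ only in methyl against bromine within the sulfonylamino group. That step was a 3.7-fold lower number from compound 1 to compound 3 (0.56 log units; beyond the scatter), a modest drop. The benzoxazolylsulfanyl step to compound 2 is a different group type and bears less directly.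

For compound 4 a downward step of about the size seen for compound 3 is therefore expected, roughly a 3.8-fold lower number from compound 1 to compound 4 (0.58 log units; beyond the scatter). The estimated value for compound 4 in this assay is 12000 nM, with a range of 5000 nM to 30000 nM.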

Compound 4, half-maximal inhibitory concentration: 12500 nM
Compound 4: the middle estimate sits 1.0-fold (0.02 log units) below what was measured, and the stated range covers the measured number.
By their numbers in this assay, from the lowest: compound 2; then compounds 3 and 4 (each within the scatter of the next); then compound 1.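

In this assay, bromo in place of methyl on an aromatic carbon gives a 1.0-fold higher number from compound 3 to compound 4 (0.00 log units; within the scatter), so compound 3 and compound 4 cannot be told apart and the choice between these two groups does not register in this read-out. The gain over phenoxy therefore holds for a second sulfonylamino member, with a 3.6-fold lower number from compound 1 to compound 4 (0.56 log units; beyond the scatter), while a 2.5-fold higher number from compound 2 to compound 4 (0.39 log units; beyond the scatter) shows that neither of the two sulfonylamino groups reaches the (1,3-benzoxazol-2-yl)sulfanyl group of compound 2, which keeps the lowest number of the four in this assay. No measurement on hand accounts for any of these steps.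

With only methyl and bromo shown on that aromatic carbon, it remains open whether an amine, a carboxylic acid or a methoxy group there would also leave the number where it stands, or whether the flat result is limited to these two groups. Also open, going by these compounds, is what carries the lower number of compound 2, the sulfur link or the fused ring system, which a (1,3-benzoxazol-2-yl)oxy group on the same saturated chain carbon would help to separate.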